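The compounds below may be only part of what the source reports. "The series", "measured", "known", "first", "only" and "open" are said of these compounds alone.

Two compounds carry a shared core with a chlorine and a substituted amino group and differ in the attachment on the sugar ring. Compound 1 `C=C[C@H]1O[C@@H](n2cnc3c(NOC)nc(Cl)nc32)[C@H](O)[C@@H]1O` gives 20 nM in an assay on HEK293 cells for binding affinity to adenosine receptor A3 (Homo sapiens); a lower number here means a stronger inhibitor, a higher number a weaker inhibitor. Compound 2 `O[C@@H]1[C@H](O)[C@@H](c2ccon2)O[C@H]1n1cnc2c(NCc3cccc(I)c3)nc(Cl)nc21` gives 7.8 nM in this assay, the lowest of the two numbers; compound 1 is the nearest, with a higher number beyond the usual scatter.

Compound 3 `CONc1nc(Cl)nc2c1ncn2[C@@H]1O[C@H](c2ccon2)[C@@H](O)[C@H]1O` has not yet been measured. It differs from compound 2 by one change: methoxy in place of 3-iodobenzyl on a nitrogen on an aromatic ring, so that a methoxyamino group replaces the (3-iodobenzyl)amino group. Compound 1 already carries that methoxyamino group and gives 20 nM, which is a weaker result than compound 2 shows.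

Resting on that, compound 3 is expected to bind more weakly than compound 2, with an estimated step of a 4.5-fold higher number from compound 2 to compound 3 (0.65 log units; beyond the scatter). For compound 3 the estimate is 35 nM, within a range from 10 nM to 130 nM.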

Compound 3, inhibition constant: 31 nM
Compound 3: the middle estimate sits 1.1-fold (0.05 log units) above what was measured; low and high end bracket the measured number.
By their numbers in this assay, from the lowest: compound 2; then compounds 1 and 3 (each within the scatter of the next).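

Among these compounds, with the 1,2-oxazol-3-yl group held fixed, methoxy in place of 3-iodobenzyl on the nitrogen gives a 4.0-fold higher number from compound 2 to compound 3 (0.60 log units; beyond the scatter) in this assay, the first comparison that isolates this position: the change is modest, but the 3-iodobenzyl compound binds more strongly. With methoxyamino held fixed, 1,2-oxazol-3-yl in place of vinyl on a saturated ring carbon gives a 1.6-fold higher number from compound 1 to compound 3 (0.19 log units; within the scatter) and so cannot be told apart from no change in this assay. No accompanying measurement gives a reason for either result.

Still open, as far as these compounds go, is whether the benefit comes from the benzyl ring or the iodine, a question that a plain benzyl group on that nitrogen would help to answer. Also open, from the compounds shown here alone, is whether 3-iodobenzyl has the same effect when vinyl replaces 1,2-oxazol-3-yl on the sugar ring.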